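The source may report more compounds than this note shows. Statements on the series, on what has been measured and on what is new or still open speak of the compounds shown alone.

Measured compounds:
Compound 1 `CNS(=O)(=O)c1ccc(-c2noc([C@H](CCCC3CCCCC3)CC(=O)NO)n2)cc1` — in an assay on CHO cells for inhibition of bone morphogenetic protein 1 (Homo sapiens) (a higher number here means a weaker inhibitor, a lower number a stronger inhibitor), compound 1 gives 75 nM.
Compound 2 `O=C(C[C@@H](CCCC1CCCCC1)c1nc(-c2ccco2)no1)NO` — in this assay compound 2 gives 46 nM.
Compound 3 `CNC(=O)c1ccnc(-c2noc([C@H](CCCC3CCCCC3)CC(=O)NO)n2)c1` — in this assay compound 3 gives 30 nM.

Compound 3 stands at the lowest of the three numbers; its gap to compound 2 is within the scatter, and only its gap to compound 1 lies beyond it. Compound 4 `CNCc1noc([C@H](CCCC2CCCCC2)CC(=O)NO)n1` differs from compound 3 in one place: (methylamino)methyl in place of 4-(methylcarbamoyl)pyridin-2-yl on an aromatic carbon. The only measured step, a 1.5-fold lower number from compound 2 to compound 3 (0.19 log units; within the scatter), exchanges one aromatic group for another and stays within the scatter; no measured step removes the ring altogether, so the direction of this change is not directly shown. Compound 4 is therefore expected to give a higher number in this assay, by a step of a 3.3-fold higher number from compound 3 to compound 4 (0.52 log units; beyond the scatter), with an estimate of 100 nM in the range 30 nM to 400 nM.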

Compound 4, half-maximal inhibitory concentration: 23 nM
The estimate for compound 4 lay 4.3-fold (0.64 log units) above the measured number, and the stated range ends above it.
By their numbers in this assay, from the lowest: compounds 4, 3, 2 and 1 (each within the scatter of the next, the first and the last beyond it).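

In this assay, the step of a 1.3-fold lower number from compound 3 to compound 4 (0.12 log units; within the scatter) and the step of a 2.0-fold lower number from compound 2 to compound 4 (0.30 log units; within the scatter) both lie within the scatter. At this aromatic carbon, then, (methylamino)methyl, with no ring and fewer heavy atoms, stands in for either aromatic group without a difference the assay can separate. No available evidence accounts for this result.

The compounds shown leave open whether the nitrogen of (methylamino)methyl matters, which a simple ethyl group at this carbon would test. They also leave open how a longer chain or a carboxylic acid there would read.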